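A few compounds are considered here, and "the series" means these few. Any claim that something is new, unique, unknown or untested is made for them only; others in the source may bear on it.

Within the data shown here, in a physicochemical assay for solubility, at pH 6.8 (on this read-out lower numbers stand for lower solubility and higher numbers for higher solubility), only two compounds have been measured so far. Compound 1 `O=C(NCc1cccnc1)Nc1ccc(CNC(=O)c2ccc(CN3CCNCC3)cc2)cc1` gives > 1000000 nM, and this is a limit of the assay, not a number. Among the measured compounds shown here, compound 2 `C[C@H](NC(=O)[C@@H]1CCCN1C)c1ccc(NC(=O)[C@H]2C[C@@H]2c2cccnc2)cc1` gives 730000 nM, the only true number available, so there is no other exact value to rank it against.

Compound 3 `C[C@H](NC(=O)c1ccccn1)c1ccc(NC(=O)[C@H]2C[C@@H]2c2cccnc2)cc1` differs from compound 2 in one place, with pyridin-2-yl in place of 1-methylpyrrolidin-2-yl on a carbonyl carbon. The swap replaces a five-membered non-aromatic ring with a six-membered aromatic ring, and the defined stereocentre of the leaving group is gone. For the measured compounds named here, no measured pair shows what such a swap does, so any forecast here is a judgement. Compound 2, at 730000 nM, already sits high on this scale, which leaves far more room for a fall than for a rise. A drop beyond the usual scatter of repeat measurements is therefore expected, and the estimated step is a 9.1-fold lower number from compound 2 to compound 3 (0.96 log units; beyond the scatter). With so little to go on, the expected range is wide. In this assay, the estimate for compound 3 is 80000 nM, within an expected range of 15000 nM to 350000 nM.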

Compound 3, solubility: 10000 nM
The estimate for compound 3 lay 8.0-fold (0.90 log units) above the measured number; measured number below the stated range.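

Among these compounds, on a carbonyl carbon whose other neighbour is an amide-type nitrogen, a single swap of pyridin-2-yl for 1-methylpyrrolidin-2-yl moves this assay by a large amount, giving the first step that can be read here: a 73-fold lower number from compound 2 to compound 3 (1.86 log units; beyond the scatter). The counted features of the two groups are the same, with 6 heavy atoms (5 carbon, 1 nitrogen), 0 hydrogen-bond donors, 1 hydrogen-bond acceptor and no net charge, so these counts do not separate them; what differs is a five-membered non-aromatic ring with a defined stereocentre against a six-membered aromatic ring with none. Compound 1 stands at a limit of the assay, which is not a number, so it offers no exact value for comparison: the limit of > 1000000 nM in this assay, at which 1 of the 3 values shown sits.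

The compounds shown cannot tell whether ring size, aromatic character or the loss of the stereocentre accounts for the step, since all three change together in this one swap. On these data alone, a piperidin-2-yl ring or an open-chain amine on the same carbonyl carbon would begin to pull these apart, and whether the step would be of similar size on another core also remains open.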